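Butyl to Isopropyl: Expected Effect on Cell Growth Inhibition

The source may hold more compounds than are shown below. What is called first, only, known or untested is meant among the compounds shown, and "the series" means these compounds.

Measured compounds:
Compound 1 `CCCCn1cnc2c(Nc3cccc(Cl)c3)nc(NCOCc3ccc(/C=C/C(=O)Nc4ccccc4N)cc3)nc21` gives 10.9%
Compound 2 `CCCCn1cnc2c(NCc3ccc(C(=O)Nc4ccccc4N)cc3)nc(Cl)nc21` gives 40.9%
Compound 3 `CC(C)n1cnc2c(Nc3cccc(Cl)c3)nc(NCOCc3ccc(/C=C/C(=O)Nc4ccccc4N)cc3)nc21` gives 27.9%

All three were tested in a functional assay on HCT-116 cells (Homo sapiens) for antiproliferative activity, read by CCK-8 assay, with a stated time of 72 h, tested at 8 uM; a higher number here means a stronger effect of the compound at the concentration tested, a lower number a weaker effect. Compound 2 shows the highest number of the three, and both compound 3 and compound 1 fall beyond the scatter below it. Compound 1 and compound 3 share one core and differ in a single place, (isopropyl in place of butyl on an aromatic nitrogen), which produced a number 17 percentage points higher from compound 1 to compound 3 (beyond the scatter). Compound 4 `CC(C)n1cnc2c(NCc3ccc(C(=O)Nc4ccccc4N)cc3)nc(Cl)nc21` has not been measured; it arises from compound 2 by the same change, (isopropyl in place of butyl on an aromatic nitrogen). How the core of compound 2 differs from the core of compound 1 is not broken down here, so the earlier step need not carry over in full. Resting on a number 17 percentage points higher from compound 1 to compound 3 (beyond the scatter), the expected step is a number 9.1 percentage points higher from compound 2 to compound 4 (within the scatter), somewhat smaller than that earlier step. Compound 4 is therefore estimated at 50%, with a likely range from 35% to 65%.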

Compound 4, a percentage reported as inhibition, at one concentration (the size of the read-out at that concentration, not a potency): 76%
Compound 4: middle estimate off by 26 percentage points, on the low side, outside the stated range (above it).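

Isopropyl in place of butyl gives a number 35.1 percentage points higher from compound 2 to compound 4 (beyond the scatter) in this assay and so moves the same way as a number 17 percentage points higher from compound 1 to compound 3 (beyond the scatter) on the other core. The direction of the change therefore held on both cores, but two cores cannot show what sets the size of the step or whether that direction would hold on a third core. The size itself did not carry over from one core to the other: the same change on two cores in this assay, a number 17 percentage points higher (beyond the scatter) from compound 1 to compound 3 and a number 35.1 percentage points higher (beyond the scatter) from compound 2 to compound 4, 18.1 percentage points apart, beyond the scatter of two such steps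

The compounds shown leave open how other groups on this aromatic nitrogen would behave, such as a propyl chain, a cyclopentyl ring or a chain ending in an amine. They also leave open whether a smaller group, such as methyl, would continue the trend.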